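Adding a methyl next to the hydroxyl: the other mirror form

The source may hold more compounds than are shown below. What is called first, only, known or untested is meant among the compounds shown, and "the series" means these compounds.

Compound 1 `CCCCCCCCc1ccc(NC(=O)[C@H](N)CO)cc1` gives 5000 nM in an assay on isolated protein for inhibition of sphingosine kinase 1 (Homo sapiens), read by mobility shift assay (a higher number here means a weaker inhibitor, a lower number a stronger inhibitor), the highest of the two numbers measured. Compound 2 `CCCCCCCCc1ccc(NC(=O)[C@H](N)[C@H](C)O)cc1` gives 2100 nM, and the step of a 2.4-fold lower number from compound 1 to compound 2 (0.38 log units; beyond the scatter) is modest. Among the measured compounds shown here, compound 3 `CCCCCCCCc1ccc(NC(=O)[C@H](N)[C@@H](C)O)cc1` carries the change (methyl in place of hydrogen on a saturated chain carbon bound to an oxygen on a saturated carbon and a saturated chain carbon); it bears the same methyl as compound 2 but in the opposite spatial arrangement at that carbon, which no measured step covers. For the measured compounds named here, the only step that bears on it is the one from compound 1 to compound 2, so only a small move is expected: a 1.1-fold lower number from compound 1 to compound 3 (0.05 log units; within the scatter), leaving compound 3 at an estimated 4500 nM, within 1500 nM to 14000 nM.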

Compound 3, half-maximal inhibitory concentration: 1600 nM
Compound 3: middle estimate off by 2.8-fold (0.45 log units), on the high side, within the range that was stated.
By their numbers in this assay, from the lowest: compounds 3 and 2 (each within the scatter of the next); then compound 1.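

The methyl on this saturated chain carbon lowers the number in both spatial arrangements, not just the one seen first: there is now a 3.1-fold lower number from compound 1 to compound 3 (0.49 log units; beyond the scatter). Switching the arrangement at that carbon gives a 1.3-fold lower number from compound 2 to compound 3 (0.12 log units; within the scatter), so this assay does not separate the two methyl forms: the fact that compounds 2 and 3 differ only in the configuration as drawn

As far as these compounds go, whether an ethyl at this carbon would lower the number further remains open. So does the role of the hydroxyl itself, which an amine or a methoxy in its place would help to test.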